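Changing one arm on the shared core of compound 3

A few compounds are considered here, and "the series" means these few. Any claim that something is new, unique, unknown or untested is made for them only; others in the source may bear on it.

Measured compounds:
compound 1 `NS(=O)(=O)c1cc(-c2nnc(CN3CCN(Cc4ccccc4)CC3)o2)c(Cl)cc1SCc1ccccc1`: 26000 nM
compound 2 `NS(=O)(=O)c1cc(-c2nnc(CN3CCN(c4ccc(F)cc4)CC3)o2)c(Cl)cc1SCc1ccccc1`: 34000 nM
compound 3 `CC(C)(O)c1cn(Cc2nnc(-c3cc(S(N)(=O)=O)c(SCc4ccccc4)cc3Cl)o2)nn1`: 82000 nM

In a functional assay on HCT-116 cells (Homo sapiens) for cytotoxicity, read by MTT assay, with a stated time of 72 h (on this read-out lower numbers stand for stronger inhibition and higher numbers for weaker inhibition), compound 3 stands highest of the three numbers; compound 2 is nearest to it and compound 1 furthest, both gaps beyond the scatter. Compound 4 `NS(=O)(=O)c1cc(-c2nnc(/C=C/c3c(Cl)cccc3Cl)o2)c(Cl)cc1SCc1ccccc1` differs from compound 3 in one place: 2-(2,6-dichlorophenyl)ethenyl in place of (4-(1-hydroxy-1-methylethyl)-1H-1,2,3-triazol-1-yl)methyl on an aromatic carbon. Among the measured compounds shown here, the only measured step, a 1.3-fold higher number from compound 1 to compound 2 (0.12 log units; within the scatter), alters a different part of the molecule, so no measured pair probes the position changed here. Compound 4 is therefore expected, with little guidance, to land among the numbers shown, estimated at 30000 nM with a range from 10000 nM to 90000 nM. That corresponds to an expected 2.7-fold lower number from compound 3 to compound 4 (0.44 log units; beyond the scatter).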

Compound 4, half-maximal inhibitory concentration: 32000 nM
For compound 4 the middle estimate is 1.1-fold (0.03 log units) below the measured one; measured number inside the range.
By their numbers in this assay, from the lowest: compounds 1, 4 and 2 (each within the scatter of the next); then compound 3.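

Among the compounds shown here, replacing (4-(1-hydroxy-1-methylethyl)-1H-1,2,3-triazol-1-yl)methyl with 2-(2,6-dichlorophenyl)ethenyl gives a 2.6-fold lower number from compound 3 to compound 4 (0.41 log units; beyond the scatter) in this assay, so this position, which no earlier pair probed, does move the number, though modestly. The entering group has no hydrogen-bond donors or acceptors, yet compound 4 lies within the scatter of compounds 1 and 2. Nothing available accounts for the step.

On these data alone, it remains open whether a carboxylic acid or a simple amine on this arm would shift the number further, and whether a saturated ethyl link would match the ethenyl one.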